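Swapping a Benzofuran Acyl Cap for a Dienoyl Cap

This account rests on a few compounds, and the source may have more. Where it says the series, first, only, none or still open, it means among the compounds named here.

Three measured compounds share a core carrying an acyl group on one nitrogen and a long alkyl chain on the other amide. Compound 1 `C/C=C/C=C/C(=O)N[C@H](C(=O)NCCCCCCCC)[C@@H](C)O` bears the penta-1,3-dien-1-yl acyl group and an octyl chain; in a functional assay on HepG2 cells (Homo sapiens) for cytotoxicity, read by MTT assay, with a stated time of 48 h (on this read-out higher numbers stand for weaker inhibition and lower numbers for stronger inhibition), compound 1 gives 102000 nM. Compound 2 `CCCCCCCCCCCCNC(=O)[C@@H](NC(=O)c1cc2ccccc2o1)[C@@H](C)O` carries a 1-benzofuran-2-yl acyl group and a dodecyl chain, and in this assay compound 2 gives 22900 nM. Compound 3 `CCCCCCCCCCCCCCNC(=O)[C@@H](NC(=O)c1cc2ccccc2o1)[C@@H](C)O` lengthens that chain to tetradecyl; in this assay compound 3 gives 23400 nM. Among the three numbers compound 3 stands second highest, close to compound 2 and apart from compound 1, whose number is higher.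

The step of a 1.0-fold higher number from compound 2 to compound 3 (0.01 log units; within the scatter) shows that an ethyl in place of a hydrogen far along the chain left the read-out essentially unchanged. Compound 4 `C/C=C/C=C/C(=O)N[C@H](C(=O)NCCCCCCCCCCCCCC)[C@@H](C)O` keeps the tetradecyl chain of compound 3 and changes the acyl group: penta-1,3-dien-1-yl in place of 1-benzofuran-2-yl on a carbonyl carbon. Going by the values given here, no measured pair isolates this exact exchange. Compound 1, which already carries the penta-1,3-dien-1-yl group, has a higher number than compounds 2 and 3, and since chain extension in a 1.0-fold higher number from compound 2 to compound 3 (0.01 log units; within the scatter) barely moved the read-out, the swap is expected to raise the number. The expected step is a 3.0-fold higher number from compound 3 to compound 4 (0.48 log units; beyond the scatter). Compound 4 is therefore estimated at 70000 nM, within a range from 25000 nM to 200000 nM.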

Compound 4, half-maximal inhibitory concentration: > 400000 nM
Compound 4 ended at the assay's limit; the forecaster's own chance of this, stated with the estimate: 15%; middle value at least 5.7-fold (0.75 log units) away from the limit.
By their numbers in this assay, from the lowest: compounds 2 and 3 (each within the scatter of the next); then compound 1. At a limit, above all of these: compound 4.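

In this assay, compound 4 gives > 400000 nM, which is a limit of the assay and not a number: the limit of > 400000 nM in this assay, at which 1 of the 4 values shown sits.

With the tetradecyl chain held fixed, exchanging 1-benzofuran-2-yl for penta-1,3-dien-1-yl on a carbonyl carbon gives an at least 17-fold higher number from compound 3 to compound 4 (1.23 log units; beyond the scatter), so the group at this position has a large bearing on the read-out, and a higher number here means weaker inhibition. The chain also proves able to matter: going from the octyl chain to the tetradecyl chain with penta-1,3-dien-1-yl in place gives an at least 3.9-fold higher number from compound 1 to compound 4 (0.59 log units; beyond the scatter), while the shorter extension from dodecyl to tetradecyl with 1-benzofuran-2-yl in place gave a 1.0-fold higher number from compound 2 to compound 3 (0.01 log units; within the scatter).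

The two chain steps differ in both their acyl group and their starting length, so an octyl chain paired with 1-benzofuran-2-yl would be needed to tell these influences apart. Going by these compounds, it also remains open whether a plain phenyl group on the same carbonyl carbon would read close to compound 3 or close to compound 4, which would show whether the full 1-benzofuran-2-yl group is needed.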